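This account rests on a few compounds, and the source may have more. Where it says the series, first, only, none or still open, it means among the compounds named here.

Measured compounds:
- compound 1, `Cc1ccc(C(=O)NC(=S)NNc2ncnc3ccccc23)cc1`, 17200 nM
- compound 2, `COc1cc2ncnc(NNC(=S)NC(=O)c3cccc(Cl)c3)c2cc1OC`, 7460 nM

Of the compounds shown here, two have been tested in a functional assay on CNE-2 cells (Homo sapiens) for cytotoxicity, read by MTT assay, with a stated time of 72 h; on this read-out lower numbers stand for stronger inhibition and higher numbers for weaker inhibition. Compound 1 gives 17200 nM, which is the highest of the two numbers. Compound 2 gives 7460 nM, a lower number; the two compounds differ in more than one place, so their values are compared only as they stand, and no single change can be read from them.

Compound 3, `Cc1ccccc1C(=O)NC(=S)NNc1ncnc2ccccc12`, has not yet been measured in this assay. It has the same atoms as compound 1, joined differently: 2-methylphenyl in place of 4-methylphenyl on a carbonyl carbon. Among the compounds with values here, nothing in the measured pair speaks to such a change, since no two measured compounds differ only there. Within the data shown here, with no step of this kind to lean on, the expectation for the step from compound 1 to compound 3 is one of no change beyond the scatter, a 1.0-fold lower number from compound 1 to compound 3 (0.01 log units; within the scatter), in this assay.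

On that basis compound 3 is expected to give about 17000 nM in this assay, within a range from 6000 nM to 50000 nM.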

Compound 3, half-maximal inhibitory concentration: 5460 nM
The estimate for compound 3 lay 3.1-fold (0.49 log units) above the measured number, and the stated range ends above it.
By their numbers in this assay, from the lowest: compounds 3 and 2 (each within the scatter of the next); then compound 1.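

In this assay the exchange of 4-methylphenyl for 2-methylphenyl on the carbonyl carbon brings a 3.2-fold lower number from compound 1 to compound 3 (0.50 log units; beyond the scatter) with no other change to the structure. This is the first step in the series shown that can be read at a single place, and it shows that the number at this position depends on how the same atoms are joined, not only on which atoms are present, though the step counts as modest. Nothing at hand explains this difference.

From the compounds shown here alone, it remains open whether the lower number belongs to the methyl group itself or would also come with a 2-chlorophenyl or 2-methoxyphenyl group on the same carbonyl carbon, and what a 3-methylphenyl group would give there. Also open, going by these compounds, is whether the same exchange would bring a similar step on the core of compound 2, so the result holds for this one pair and for the core of compound 1 alone.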